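Swapping an isopropyl thioether for a 3-methylbenzyl

A few compounds are considered here, and "the series" means these few. Any claim that something is new, unique, unknown or untested is made for them only; others in the source may bear on it.

Compound 3 `CC(C)Sc1n[nH]c(-n2[se]c3ccccc3c2=O)n1` gives the lowest number shown, 6010 nM in a functional assay on SMMC-7721 cells (Homo sapiens) for antiproliferative activity, read by CCK-8 assay, with a stated time of 48 h; a lower number here means a stronger inhibitor, a higher number a weaker inhibitor. Compound 2 `O=c1c2ccccc2[se]n1-c1nc(SCc2ccc(F)cc2)n[nH]1` gives 46100 nM in this assay. Compound 1 `Cc1ccc(CSc2n[nH]c(-n3[se]c4ccccc4c3=O)n2)cc1` reaches only the assay limit, > 50000 nM, in this assay. Compound 4 `Cc1cccc(CSc2n[nH]c(-n3[se]c4ccccc4c3=O)n2)c1` differs from compound 3 by 3-methylbenzyl in place of isopropyl on a sulfur. The two steps that bear on this change run the other way: an at least 8.3-fold lower number from compound 1 to compound 3 (0.92 log units; beyond the scatter) and a 7.7-fold lower number from compound 2 to compound 3 (0.88 log units; beyond the scatter), both beyond the scatter. Reversing either of them, the number is expected to climb by a similar amount, so for compound 4 the expected step is a 6.7-fold higher number from compound 3 to compound 4 (0.82 log units; beyond the scatter). Compound 4 is therefore estimated at 40000 nM, within a range of 12000 nM to 150000 nM, and it may well again reach only the limit (the limit of > 50000 nM in this assay, at which 1 of the 3 values shown sits).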

Compound 4, half-maximal inhibitory concentration: 9040 nM
Estimate against measurement, compound 4: 4.4-fold (0.65 log units) above; the whole stated range lies above it.
By their numbers in this assay, from the lowest: compounds 3 and 4 (each within the scatter of the next); then compound 2. At a limit, above all of these: compound 1.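

In this assay, a ring on this sulfur is not in itself a loss: a 1.5-fold higher number from compound 3 to compound 4 (0.18 log units; within the scatter). Among the benzyl thioethers the ring substituent decides, with a 5.1-fold lower number from compound 2 to compound 4 (0.71 log units; beyond the scatter), and 3-methylphenyl in place of 4-methylphenyl gives an at least 5.5-fold lower number from compound 1 to compound 4 (0.74 log units; beyond the scatter). That last step is only a floor, as compound 1 stands at a limit of the assay: the limit of > 50000 nM in this assay, at which 1 of the 4 values shown sits.

As far as these compounds go, whether an unsubstituted benzyl or a 3-methoxybenzyl on this sulfur would stay level with compound 3 and compound 4 remains open. So does how a 3-fluorobenzyl would compare with compound 2.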